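The source may report more compounds than this note shows. Statements on the series, on what has been measured and on what is new or still open speak of the compounds shown alone.

Notes on the series. Compound 1 `C=C(C)[C@@H]1CC=C(Cn2cc(COc3ccc(C4NC(=O)NC5=C4C(=O)CC(C)(C)C5)cc3)nn2)CC1` and compound 2 `C=C(C)[C@@H]1CC=C(Cn2cc(COc3cccc(C4NC(=O)NC5=C4C(=O)CC(C)(C)C5)c3)nn2)CC1` have the same atoms joined differently; the difference between the two cores is not broken down here. Compound 3 `C=C(C)[C@@H]1CC=C(Cn2cc(COc3cc(C4NC(=O)NC5=C4C(=O)CC(C)(C)C5)ccc3OC)nn2)CC1` carries, relative to compound 2, the change (methoxy in place of hydrogen on an aromatic carbon). Compound 4 `C=C(C)[C@@H]1CC=C(Cn2cc(COc3ccc(C4NC(=O)NC5=C4C(=O)CC(C)(C)C5)cc3OC)nn2)CC1` carries the same kind of change relative to compound 1, (methoxy in place of hydrogen on an aromatic carbon); the surroundings differ in that the methoxy is para to a large group in compound 3 but meta to a large group in compound 4. In a functional assay on HT-29 cells (Homo sapiens) for inhibition, read by sulforhodamine B assay, with a stated time of 48 h (a lower number here means a stronger inhibitor of growth, a higher number a weaker inhibitor of growth), compound 2 gives 49000 nM. Compound 3 reaches only a limit of the assay, > 100000 nM. Compound 1 likewise reaches only a limit, > 100000 nM. Among the measured compounds shown here, the single measured instance of the change is an at least 2.0-fold higher number from compound 2 to compound 3 (0.30 log units; that floor lies within the scatter). For compound 4 a step that the limit leaves unreadable from compound 1 to compound 4 is expected, resting on (the limit of > 100000 nM in this assay, at which 2 of the 3 values shown sit). Compound 4 is accordingly estimated near 200000 nM, most probably reported again as a limit.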

Compound 4, concentration for total growth inhibition: > 100000 nM
Compound 4: a limit, no number; the forecaster's own chance of this, stated with the estimate: 85%; the middle value is on the limit's open side.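

No new step can be read from compound 1 to compound 4, since both values are limits: the limit of > 100000 nM in this assay, at which 3 of the 4 values shown sit.

The compounds shown leave open whether methoxy in place of hydrogen changes growth inhibition in the core of compound 1 at all.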